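The source may hold more compounds than are shown below. What is called first, only, known or untested is meant among the compounds shown, and "the series" means these compounds.

Compound 1 `OC[C@H]1O[C@@H](n2cnc3c(NCc4ccc(F)cc4)ncnc32)[C@H](O)[C@@H]1O`: 44300 nM
Compound 2 `OC[C@H]1O[C@@H](n2cnc3c(NCc4ccc(Cl)c(Cl)c4)ncnc32)[C@H](O)[C@@H]1O`: "not determined" (no result reported)

In an ADME assay on NIH3T3 cells (Mus musculus) for cytotoxicity, with a stated time of 72 h (a higher number here means a weaker inhibitor, a lower number a stronger inhibitor), compound 2 stands as "not determined" (no result reported), so it offers no number to start from. The structural change to compound 3 `OC[C@H]1O[C@@H](n2cnc3c(NCc4ccc(F)cc4Cl)ncnc32)[C@H](O)[C@@H]1O`, not yet measured, is 2-chloro-4-fluorophenyl in place of 3,4-dichlorophenyl on a saturated chain carbon bound to a nitrogen on an aromatic ring. Going by the values given here, no measured step shows what such a change does here, and the only number available is that of compound 1 at 44300 nM. A reading near that of compound 1 is therefore expected, with no difference beyond the scatter and no favoured direction. For compound 3 the estimated value is 38000 nM, with an expected range of 14000 nM to 90000 nM.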

Compound 3, half-maximal inhibitory concentration: > 166000 nM
Compound 3 was reported as a limit (the forecaster's own chance of this, stated with the estimate: 20%); middle value at least 4.3-fold (0.64 log units) from the limit.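

In this assay compound 3 gives > 166000 nM as a limit and not a number. Chloro in place of hydrogen on an aromatic carbon brings an at least 3.7-fold higher number from compound 1 to compound 3 (0.57 log units; beyond the scatter) and so gives the first measured effect of a change on this benzyl group, which compound 1 alone and compound 2 without a number could not show. The step has a lower bound only: the limit of > 166000 nM in this assay, at which 1 of the 3 values shown sits.

From the compounds shown here alone, whether a methyl group or an amine on that aromatic carbon would move the number the same way remains open. So does how the 3,4-dichlorobenzyl group of compound 2 compares, as it has no number.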